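This account rests on a few compounds, and the source may have more. Where it says the series, first, only, none or still open, it means among the compounds named here.

Measured compounds:
compound 1 `COc1cc(Cc2nc3c(N)ncnc3n2CC2CCCCC2)cc(OC)c1OC` — 39800 nM
compound 2 `COc1cc(Cc2nc3c(N)nc(F)nc3n2CCOC(C)C)c(Cl)c(OC)c1OC` — 5370 nM

In a functional assay on MCF7 cells (Homo sapiens) for antiproliferative activity (on this read-out lower numbers stand for stronger inhibition and higher numbers for weaker inhibition), compound 1 gives 39800 nM, the highest of the two numbers recorded. Within the data shown here, compound 2, with a value of 5370 nM, lies beyond the scatter from compound 1, but the two structures differ in several places at once, so the pair shows only that compound 2 sits well below compound 1 and nothing about any single change.

Compound 3 `COc1cc(Cc2nc3c(N)ncnc3n2CC(OC)OC)cc(OC)c1OC` has not yet been measured in this assay. It differs from compound 1 in one place: dimethoxymethyl in place of cyclohexyl on a saturated chain carbon bound to an aromatic nitrogen. Among the measured compounds shown here, no measured pair in this set isolates a change of this kind, so there is no step to lean on. Compound 3 is therefore expected to stay close to compound 1, with a step of a 1.3-fold lower number from compound 1 to compound 3 (0.12 log units; within the scatter) that is estimated to fall within the usual scatter, in either direction. On that basis compound 3 is estimated at 30000 nM in this assay, with a plausible range from 8000 nM to 100000 nM.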

Compound 3, half-maximal inhibitory concentration: 72400 nM
Compound 3: middle estimate off by 2.4-fold (0.38 log units), on the low side; the measured number falls inside the stated range.
By their numbers in this assay, from the lowest: compound 2; then compounds 1 and 3 (each within the scatter of the next).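

Among these compounds, replacing cyclohexyl with dimethoxymethyl on a saturated chain carbon bound to an aromatic nitrogen gives the first single-place comparison in this set: in this assay, the step is a 1.8-fold higher number from compound 1 to compound 3 (0.26 log units; within the scatter). The exchange removes the six-membered carbon ring and brings in two hydrogen-bond acceptors, yet the two compounds remain within the scatter of each other, so this pair shows no measurable effect of the change on the read-out. No supporting measurement bears on why the result falls this way.

This one pair cannot separate the loss of the ring from the entry of the two oxygen atoms, and a single exchange says little about the wider range of groups this place might accept. On these data alone, how an amine, a carboxylic acid or a longer chain at this place would read remains open, as does whether dimethoxymethyl in place of cyclohexyl would give a similar step on a core carrying other substituents.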